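The source may hold more compounds than are shown below. What is called first, only, known or untested is meant among the compounds shown, and "the series" means these compounds.

In a functional assay on St-4 cells (Homo sapiens) for inhibition, read by colorimetric assay and sulforhodamine B assay, with a stated time of 48 h (on this read-out higher numbers stand for weaker inhibition of growth and lower numbers for stronger inhibition of growth), compound 1 `CCCCCCCCCCCC[C@@H](O)[C@H]1CC[C@H]([C@H](O)CCCCCCCCCCNC(=O)c2cccs2)O1` gives 1820 nM, compound 2 `CCCCCCCCCCCC[C@@H](O)[C@H]1CC[C@H]([C@H](O)CCCCCCCCCCNC(=O)c2ccco2)O1` gives 100000 nM, and compound 3 `CCCCCCCCCCCC[C@@H](O)[C@H]1CC[C@H]([C@H](O)CCCCCCCCCCNC(=O)c2cncs2)O1` gives 100000 nM. Compound 3 therefore sits level with compound 2 at the weak end of these three numbers. Compound 4 `CCCCCCCCCCCC[C@@H](O)[C@H]1CC[C@H]([C@H](O)CCCCCCCCCCNC(=O)c2ccnn2C)O1` differs from compound 3 by one change on a carbonyl carbon: 1-methyl-1H-pyrazol-5-yl in place of 1,3-thiazol-5-yl on a carbonyl carbon. Earlier ring swaps at this place gave a 55-fold higher number from compound 1 to compound 2 (1.74 log units; beyond the scatter) and a 55-fold higher number from compound 1 to compound 3 (1.74 log units; beyond the scatter), but also no change at the digits printed from compound 2 to compound 3 (within the scatter). Both large steps start from compound 1, and the change to compound 4 does not restore its thiophen-2-yl group, so no step beyond the scatter is expected in this assay. The expected step is a 1.4-fold lower number from compound 3 to compound 4 (0.15 log units; within the scatter). Compound 4 is estimated at 70000 nM, with an expected range of 10000 nM to 100000 nM.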

Compound 4, concentration for 50% growth inhibition: 18200 nM
Beside the measured number, compound 4's estimate is 3.8-fold (0.59 log units) above it; measured number inside the range.
By their numbers in this assay, from the lowest: compound 1; then compound 4; then compounds 2 and 3 (each within the scatter of the next).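

In this assay, the swap gives a 5.5-fold lower number from compound 3 to compound 4 (0.74 log units; beyond the scatter) and, against the furan-2-yl compound, a 5.5-fold lower number from compound 2 to compound 4 (0.74 log units; beyond the scatter), so the ring on this carbonyl carbon can tune growth inhibition in steps smaller than those seen earlier. Thiophen-2-yl still keeps its lead, with a 10-fold higher number from compound 1 to compound 4 (1.00 log units; beyond the scatter). No measurement shown here explains these differences. Still open, on these data alone, is how a phenyl ring or a pyrazole ring lacking the methyl group would fare on this carbonyl carbon, and whether either could match or pass compound 1.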